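Sulfonamide Returns in Place of the Tetrazole

This account rests on a few compounds, and the source may have more. Where it says the series, first, only, none or still open, it means among the compounds named here.

Compound 3 `CC(O)(C(=O)Nc1ccc(-c2nn[nH]n2)cc1)C(F)(F)F` and compound 1 `CC(O)(C(=O)Nc1ccc(/C(=N\O)c2ccccc2)cc1)C(F)(F)F` share the same amide side chain. In an assay on a protein complex (Cavia porcellus) with sulfonylurea receptors; K-ATP channels (Homo sapiens) as the target (a lower number here means a stronger inhibitor, a higher number a weaker inhibitor), compound 1 gives only a limit of > 30000 nM. Compound 3 likewise gives only a limit of > 30000 nM in this assay. Compound 2 `CCN(CC)S(=O)(=O)c1ccc(NC(=O)C(C)(O)C(F)(F)F)cc1` gives 810 nM in this assay, and an at least 37-fold higher number from compound 2 to compound 3 (1.56 log units; beyond the scatter). Compound 3 thus sits at the limit of > 30000 nM in this assay, at which 2 of the 3 values shown sit. Compound 4 `CC(O)(C(=O)Nc1ccc(S(=O)(=O)N2CCCC2)cc1)C(F)(F)F` differs from compound 3 by (pyrrolidin-1-yl)sulfonyl in place of 2H-tetrazol-5-yl on an aromatic carbon. The measured step from compound 2 to compound 3 is the only one that bears on this exchange, and the present change runs the opposite way, replacing the tetrazole with a sulfonyl amide close to that of compound 2. Because an at least 37-fold higher number from compound 2 to compound 3 (1.56 log units; beyond the scatter) was large, compound 4 is expected to show an at least 33-fold lower number from compound 3 to compound 4 (1.52 log units; beyond the scatter). Compound 4 is estimated at 900 nM, between 250 nM and 4000 nM.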

Compound 4, half-maximal inhibitory concentration: 880 nM
Compound 4: middle estimate off by 1.0-fold (0.01 log units), on the high side, and the stated range covers the measured number.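

Placing (pyrrolidin-1-yl)sulfonyl on this aromatic carbon in place of 2H-tetrazol-5-yl gives an at least 34-fold lower number from compound 3 to compound 4 (1.53 log units; beyond the scatter) in this assay, so the tetrazole result can be reversed at this position. The sulfonyl group also tolerates a change in its amine, with a 1.1-fold higher number from compound 2 to compound 4 (0.04 log units; within the scatter), which leaves pyrrolidin-1-yl and diethylamino not distinguished here. The value of compound 3 is only a limit, so the first step has a bound and no exact size: the limit of > 30000 nM in this assay, at which 2 of the 4 values shown sit.

The compounds shown leave open how a morpholine or an unsubstituted amino group on the sulfonyl sulfur would read in this assay. They also leave open whether a carboxamide or a carboxylic acid at this position would match the sulfonyl groups.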